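A Fluorine Removed on the Carboxylic Acid Ring

The source may hold more compounds than are shown below. What is called first, only, known or untested is meant among the compounds shown, and "the series" means these compounds.

The study measures compounds in an assay on HEK293 cells for positive allosteric modulation of metabotropic glutamate receptor 2 (Rattus norvegicus), read by thallium flux, with a stated time of 2.5 min; on this read-out higher numbers stand for an effect only at larger amounts of compound and lower numbers for an effect already at smaller amounts. Within the data shown here, compound 2, with the structure `Cc1c(OCCCCOc2ccc(C(=O)O)c(Cl)c2)ccc(C(=O)CC2CCCC2)c1C`, is the only compound with a number: in this assay compound 2 gives 2420 nM. Compound 1, with the structure `COC(=O)c1ccc(OCCCCOc2ccc(C(=O)CC3CCCC3)c(C)c2C)cc1`, has no reported result in this assay, where compound 1 stands as "not determined" (no result reported). Compound 3, with the structure `Cc1c(OCCCCOc2ccc(F)c(C(=O)O)c2)ccc(C(=O)CC2CCCC2)c1C`, likewise stands without a number in this assay, where compound 3 stands as "not determined" (no result reported); it is one of two compounds for which no result was reported, so its position among the measured compounds cannot be placed.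

Compound 4, with the structure `Cc1c(OCCCCOc2cccc(C(=O)O)c2)ccc(C(=O)CC2CCCC2)c1C`, has not yet been measured in this assay. The difference between compound 3 and compound 4 is hydrogen in place of fluoro on an aromatic carbon. The change is a single heavy atom, fluoro, that leaves and is replaced by hydrogen.

Among the measured compounds shown here, no pair of measured compounds that differ in one place is available, so there is no measured step from which to judge the size or direction of this change in this assay. For the measured compounds named here, with compound 3 itself unmeasured, the only anchor is compound 2, whose value in this assay is 2420 nM, and compound 2 differs from compound 4 in more than one place. Compound 4 is therefore expected to give about 3000 nM in this assay, within a wide range from 700 nM to 13000 nM.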

Compound 4, half-maximal effective concentration: "not active" (no number reported)
Compound 4 has no reported number here, and the estimate cannot be compared.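

In this assay compound 3 stands as "not determined" (no result reported) and compound 4 as "not active" (no number reported), so no step can be read between them. Nothing available explains this result. The compounds shown leave open how the change from 3-carboxy-4-fluorophenyl to 3-carboxyphenyl alters the effect in this assay.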